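This account rests on a few compounds, and the source may have more. Where it says the series, first, only, none or still open, it means among the compounds named here.

Of the compounds shown here, three that share one core have been tested in a functional assay on B16-F10 cells (Mus musculus) for antiproliferative activity, read by MTT assay, with a stated time of 48 h (a lower number here means a stronger inhibitor, a higher number a weaker inhibitor), so far. Compound 1 (`COc1ccc(/C=C/c2cc(OC)cc(OC)c2/C=C/C(=O)c2ccc(Cl)c(Cl)c2)cc1`) gives 7.5 ug/mL in this test, compound 2 (`CCCC(C)Oc1ccc(C(=O)/C=C/c2c(/C=C/c3ccc(OC)cc3)cc(OC)cc2OC)cc1`) gives 6.7 ug/mL and compound 3 (`COc1ccc(/C=C/c2cc(OC)cc(OC)c2/C=C/C(=O)c2cccc(Br)c2)cc1`) gives 5.1 ug/mL under the same conditions. Compound 3 cannot be separated from the other two: the measured steps to it are a 1.5-fold lower number from compound 1 to compound 3 (0.17 log units; within the scatter) and a 1.3-fold lower number from compound 2 to compound 3 (0.12 log units; within the scatter) and both stay within the scatter.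

Compound 4 (`COc1ccc(/C=C/c2cc(OC)cc(OC)c2/C=C/C(=O)c2cccc(Cl)c2)cc1`) differs from compound 3 in a single place, with chloro in place of bromo on an aromatic carbon, meta to a large group (chloro in place of bromo on an aromatic carbon). Going by the values given here, no measured pair makes this exact exchange, so the evidence is indirect. The three measured compounds differ in the group on the carbonyl carbon, and a 1.1-fold lower number from compound 1 to compound 2 (0.05 log units; within the scatter) also stays within the scatter. Even the exchange of the whole group in a 1.3-fold lower number from compound 2 to compound 3 (0.12 log units; within the scatter) did not produce a step beyond the scatter, and the change in compound 4 is a smaller one.

The expected size is a 1.1-fold higher number from compound 3 to compound 4 (0.06 log units; within the scatter) and no clear shift in either direction is anticipated. For compound 4 the estimated value is 5.8 ug/mL with an expected range from 3.3 ug/mL to 10 ug/mL in this test.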

Compound 4, half-maximal inhibitory concentration: 3.3 ug/mL
Compound 4: the middle estimate sits 1.8-fold (0.24 log units) above what was measured; the measured number falls inside the stated range.
By their numbers in this assay, from the lowest: compounds 4, 3, 2 and 1 (each within the scatter of the next, the first and the last beyond it).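

In this assay, exchanging bromo for chloro on this aromatic carbon gives a 1.5-fold lower number from compound 3 to compound 4 (0.19 log units; within the scatter), so the two halogens cannot be told apart at this position. Going by these compounds alone, what is new is that compound 4 is the first compound to stand clear of others, with a 2.0-fold lower number from compound 2 to compound 4 (0.31 log units; beyond the scatter) and a 2.3-fold lower number from compound 1 to compound 4 (0.36 log units; beyond the scatter), both modest, whereas every step among the first three compounds stayed within the scatter. Compound 3 does not stand clear of compound 1 or compound 2. This separation belongs to compound 4 alone and gives no ranking of chloro over bromo. Nothing measured here explains these differences.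

The compounds shown leave open whether this position accepts groups of a different kind, such as an amine, a carboxylic acid, a methoxy group or a longer chain, or whether the ring does as well with plain hydrogen there. With only two halogens compared at this position, fluoro and iodo would show whether any trend exists across the halogen series or whether the values in this assay stay within the scatter of one another.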